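A few compounds are considered here, and "the series" means these few. Any claim that something is new, unique, unknown or untested is made for them only; others in the source may bear on it.

Three compounds share one core, differing in the aryl group that sits on a double-bonded chain carbon bound to a double-bonded chain carbon, and in the linker to the outer ring system. Compound 1 `COc1ccccc1/C=C/C(=O)/C=C/c1ccc(OCc2cn(CCCOc3cc(=O)oc4ccccc34)nn2)c(OC)c1` gives 57% in a functional assay on COLO 205 cells (Homo sapiens) for inhibition, read by sulforhodamine B assay, with a stated time of 48 h, tested at 50 uM (a higher number here means more inhibition of growth at the concentration tested, a lower number less inhibition of growth), the highest of the three numbers shown. Compound 3 `COc1cc(/C=C/C(=O)/C=C/c2cc(OC)c(OC)c(OC)c2)ccc1OCc1cn(CCCCCOc2cc(=O)oc3ccccc23)nn1` gives 51% in this assay, within the scatter of compound 1. Compound 2 `COc1ccc(/C=C/C(=O)/C=C/c2ccc(OCc3cn(CCCCCOc4cc(=O)oc5ccccc45)nn3)c(OC)c2)cc1` gives 30% in this assay, beyond the scatter below compound 1.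

Compound 4 `COc1cc(/C=C/C(=O)/C=C/c2cccc3ccccc23)ccc1OCc1cn(CCCOc2cc(=O)oc3ccccc23)nn1` differs from compound 1 in one place: naphthalen-1-yl in place of 2-methoxyphenyl on a double-bonded chain carbon bound to a double-bonded chain carbon. Going by the values given here, the only measured step at that same place is a number 21 percentage points higher from compound 2 to compound 3 (beyond the scatter), which swapped one methoxy-bearing ring for another; it shows that the aryl group there can shift the number modestly, but no measured step introduces a naphthalen-1-yl group. The expectation for compound 4 is therefore a step of a number 7 percentage points lower from compound 1 to compound 4 (within the scatter), that is, no change beyond the scatter, with wide uncertainty. Compound 4 is estimated at 50%, between 30% and 70%.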

Compound 4, percent growth inhibition at one concentration: 64%
Compound 4: middle estimate off by 14 percentage points, on the low side; measured number inside the range.
By their numbers in this assay, from the lowest: compound 2; then compounds 3, 1 and 4 (each within the scatter of the next, the first and the last beyond it).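

In this assay, putting naphthalen-1-yl in place of 2-methoxyphenyl on a double-bonded chain carbon bound to a double-bonded chain carbon gives a number 7 percentage points higher from compound 1 to compound 4 (within the scatter). Going by these compounds alone, the earlier step at this place swapped only one methoxy-bearing ring for another, whereas this pair shows that a group of two six-membered aromatic rings of carbon only, with no oxygen and no hydrogen-bond acceptor, can stand there and keep the number within the scatter of compound 1. Nothing at hand shows what lies behind this result.

Still open, going by these compounds, is whether a ring carrying an amine or a carboxylic acid would hold the number at this place. No two compounds shown differ in the linker chain alone, so its contribution cannot be read.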